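The source may hold more compounds than are shown below. What is called first, only, known or untested is meant among the compounds shown, and "the series" means these compounds.

Working notes on the N-alkyl series. Three compounds carry the shared core with a tert-butyl urea and a thioether link to the nitro-substituted methoxybenzyl group; they differ only in the substituent on the ring nitrogen. Compound 1 `COc1ccc([N+](=O)[O-])cc1CSc1nc2cc(NC(=O)NC(C)(C)C)ccc2n1C1CC1` carries a cyclopropyl group and in an assay on isolated protein for inhibition of Gonadotropin-releasing hormone receptor (Homo sapiens) (a higher number here means a weaker inhibitor, a lower number a stronger inhibitor), compound 1 gives 79 nM. Compound 2 `CCn1c(SCc2cc([N+](=O)[O-])ccc2OC)nc2cc(NC(=O)NC(C)(C)C)ccc21` carries an ethyl group and gives 42 nM. Compound 3 `CCCn1c(SCc2cc([N+](=O)[O-])ccc2OC)nc2cc(NC(=O)NC(C)(C)C)ccc21` carries a propyl group and gives 18 nM, the lowest of the three numbers. The step of a 1.9-fold lower number from compound 1 to compound 2 (0.27 log units; within the scatter) is small, whereas a 4.4-fold lower number from compound 1 to compound 3 (0.64 log units; beyond the scatter) and a 2.3-fold lower number from compound 2 to compound 3 (0.37 log units; beyond the scatter) both lie beyond the scatter, so within this set a longer chain on the nitrogen has gone with a lower number.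

Compound 4 `CCCCCn1c(SCc2cc([N+](=O)[O-])ccc2OC)nc2cc(NC(=O)NC(C)(C)C)ccc21` extends the chain further: ethyl in place of hydrogen on a saturated chain carbon, three bonds along the chain from an aromatic nitrogen. Among the compounds with values here, the steps that bear on it are a 2.3-fold lower number from compound 2 to compound 3 (0.37 log units; beyond the scatter), the one-carbon homologation in the same direction, and the larger 4.4-fold lower number from compound 1 to compound 3 (0.64 log units; beyond the scatter). Adding two further carbons is a bigger change than either measured step, and nothing here shows whether the trend continues or levels off. A modest further lowering is therefore expected, but with wide uncertainty: for compound 4 the estimate is 12 nM, with a range from 4 nM to 40 nM. The expected step is a 1.5-fold lower number from compound 3 to compound 4 (0.18 log units; within the scatter).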

Compound 4, half-maximal inhibitory concentration: 210 nM
Compound 4: the middle estimate sits 18-fold (1.24 log units) below what was measured; the measured number lies above the stated range.
By their numbers in this assay, from the lowest: compound 3; then compounds 2 and 1 (each within the scatter of the next); then compound 4.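

Within the data shown here, the chain on the ring nitrogen does not keep lowering the number as it grows: a 12-fold higher number from compound 3 to compound 4 (1.07 log units; beyond the scatter) runs against a 2.3-fold lower number from compound 2 to compound 3 (0.37 log units; beyond the scatter), so in this assay the direction turns somewhere past propyl, and this is the first large step in the set. The turn also carries pentyl past the shorter groups, with a 5.0-fold higher number from compound 2 to compound 4 (0.70 log units; beyond the scatter) and a 2.7-fold higher number from compound 1 to compound 4 (0.42 log units; beyond the scatter), which leaves the propyl group of compound 3 as the lowest point of the four and shows that the earlier link between chain length and a lower number holds only as far as propyl, with compound 4 going against it. No measurement at hand accounts for this reversal.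

Going by these compounds, how a butyl group on the ring nitrogen would fall remains open, and with it where along the chain the turn lies. Also open, on these data alone, is whether a branched chain such as isobutyl, or a chain ending in a hydroxyl group or an amine, would follow compound 3 or compound 4.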